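From cycloheptyl to (furan-2-yl)methyl on the amide

The compounds below may be only part of what the source reports. "The series", "measured", "known", "first", "only" and "open" are said of these compounds alone.

Measured in a functional assay on MDA-MB-231 cells (Homo sapiens) for inhibition, read by MTT assay, with a stated time of 48 h; a higher number here means a weaker inhibitor, a lower number a stronger inhibitor:
- Compound 1 (`O=C(NC1CCC1)c1[nH]cnc1-c1nc2ccccc2[nH]1`) gives 33800 nM
- Compound 2 (`O=C(NC1CCCC1)c1[nH]cnc1-c1nc2ccccc2[nH]1`) gives 20600 nM
- Compound 3 (`O=C(NC1CCCCCC1)c1[nH]cnc1-c1nc2ccccc2[nH]1`) gives > 40000 nM, a limit and not a number

Compound 3 therefore has no exact position on the scale, only a limit. Compound 4 (`O=C(NCc1ccco1)c1[nH]cnc1-c1nc2ccccc2[nH]1`) keeps the shared core but carries (furan-2-yl)methyl in place of cycloheptyl on an amide-type nitrogen.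

Three measured steps change the group at this same place: a 1.6-fold lower number from compound 1 to compound 2 (0.22 log units; within the scatter), an at least 1.1-fold higher number from compound 1 to compound 3 (0.07 log units; that floor lies within the scatter) and an at least 1.9-fold higher number from compound 2 to compound 3 (0.28 log units; that floor lies within the scatter). The first lies within the scatter, and the floors of the other two do as well. Among the compounds with values here, no measured compound carries a furan ring, so these steps are only a rough guide. They give no reason to expect a large change.

The expectation rests on compound 1 at 33800 nM and compound 2 at 20600 nM. A modest move to a lower number is expected, estimated as an at least 1.6-fold lower number from compound 3 to compound 4 (0.22 log units; that floor lies within the scatter). Compound 4 is estimated at 24000 nM, with an expected range of 10000 nM to 40000 nM.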

Compound 4, half-maximal inhibitory concentration: 22200 nM
For compound 4 the middle estimate is 1.1-fold (0.03 log units) above the measured one; the measured number falls inside the stated range.
By their numbers in this assay, from the lowest: compounds 2, 4 and 1 (each within the scatter of the next). At a limit, above all of these: compound 3.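

In this assay, within the data shown here, (furan-2-yl)methyl is the first group at this place to bring an aromatic ring, an oxygen atom and a hydrogen-bond acceptor, yet compound 4 cannot be told apart from the two cycloalkyl amides with exact values: a 1.1-fold higher number from compound 2 to compound 4 (0.03 log units; within the scatter) and a 1.5-fold lower number from compound 1 to compound 4 (0.18 log units; within the scatter). Against the cycloheptyl amide, the reading is an at least 1.8-fold lower number from compound 3 to compound 4 (0.25 log units; that floor lies within the scatter). This step is only a floor, because compound 3 has a limit and not an exact number: the limit of > 40000 nM in this assay, at which 1 of the 4 values shown sits.

The compounds shown leave open whether any group on this amide nitrogen can move the number beyond the scatter. A basic amine, a carboxylic acid or a longer chain in this place would test that, and a plain benzyl group would separate the effect of the oxygen atom from that of the aromatic ring.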